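From bromo to chloro in compound 2

This account rests on a few compounds, and the source may have more. Where it says the series, first, only, none or still open, it means among the compounds named here.

Values in a functional assay on HepG2 cells (Homo sapiens) for antiproliferative activity, read by MTT assay, with a stated time of 48 h; a higher number here means a weaker inhibitor, a lower number a stronger inhibitor
Compound 1 `Brc1cccc(Nc2ncnc3ccc(NCc4ccccc4Br)cc23)c1` gives 2760 nM
Compound 2 `COc1ccc(CNc2ccc3ncnc(Nc4cccc(Br)c4)c3c2)cc1` gives 5430 nM
Compound 3 `Oc1ccccc1CNc1ccc2ncnc(Nc3cccc(Cl)c3)c2c1` gives 2080 nM

Compound 2 stands at the upper end of these three numbers. Compound 1 cannot be told apart from it, while compound 3 lies lower by more than the scatter. Compound 4 `COc1ccc(CNc2ccc3ncnc(Nc4cccc(Cl)c4)c3c2)cc1` departs from compound 2 at a single place: chloro in place of bromo on an aromatic carbon.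

Within the data shown here, no measured step makes this exchange. Among the measured compounds shown here, the only measured step, a 2.0-fold higher number from compound 1 to compound 2 (0.29 log units; within the scatter), puts 4-methoxyphenyl in place of 2-bromophenyl and so concerns a different place, leaving the bromo untouched. Compound 3 already carries the 3-chlorophenyl, but it differs from compound 2 in more than one place, so its lower value cannot be assigned to the halogen alone. That value allows at most a slight lean downward. No step beyond the scatter is therefore expected in this assay. The expected size is a 1.3-fold lower number from compound 2 to compound 4 (0.10 log units; within the scatter), with no clear direction to be claimed. Compound 4 is estimated at 4300 nM, with an expected range from 2100 nM to 8800 nM as the close of this account.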

Compound 4, half-maximal inhibitory concentration: 5260 nM
Compound 4: the middle estimate sits 1.2-fold (0.09 log units) below what was measured; the range from low to high includes it.
By their numbers in this assay, from the lowest: compounds 3, 1, 4 and 2 (each within the scatter of the next, the first and the last beyond it).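

In this assay the 3-bromophenyl and the 3-chlorophenyl cannot be told apart when 4-methoxyphenyl stands at the other end of the molecule: the exchange gives a 1.0-fold lower number from compound 2 to compound 4 (0.01 log units; within the scatter). With the chloro now held constant, the 2-hydroxyphenyl and the 4-methoxyphenyl can be compared directly, and that change gives a 2.5-fold higher number from compound 3 to compound 4 (0.40 log units; beyond the scatter), so the lower value of compound 3 goes with its 2-hydroxyphenyl and not with its chloro. Nothing measured on these groups bears on either step, so neither can be given a cause.

Among the compounds shown, the comparison of bromo with chloro rests on the 4-methoxyphenyl pair alone, so it remains open whether the two halogens also match when 2-hydroxyphenyl or 2-bromophenyl stands at the other end. Also open, on these data alone, is how the value would move if a group other than a halogen, such as a nitrile or an amine, stood in place of the chloro on this aromatic carbon.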